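This account rests on a few compounds, and the source may have more. Where it says the series, first, only, none or still open, it means among the compounds named here.

Of the compounds shown here, three built on one shared core have been tested in a functional assay with platelet-activating factor receptor (Cavia porcellus) as the target; on this read-out higher numbers stand for an effect only at larger amounts of compound and lower numbers for an effect already at smaller amounts. Compound 1 `CCCC/C(=C\C=C\C(=O)N[C@H](C)CCCc1cccnc1)c1ccc(OC)cc1` gives 0.68 mg/kg. Compound 2 `O=C(/C=C/C=C(c1ccc(F)cc1)c1ccc(F)cc1)NCCCCc1cccnc1` gives 0.38 mg/kg. Compound 3 `C[C@H](CCCc1cccnc1)NC(=O)/C=C/C=C(c1cccc(F)c1)c1cccc(F)c1` gives 0.22 mg/kg. Compound 1 thus has the highest of the three numbers; its gap to compound 2 lies within the scatter of repeated measurements, while its gap to compound 3 lies beyond it.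

Compound 4 `CCC/C(=C\C=C\C(=O)N[C@H](C)CCCc1cccnc1)c1ccc(OC)cc1` differs from compound 1 in one place: hydrogen in place of methyl on a saturated chain carbon, three bonds along the chain from a double-bonded chain carbon, which cut one bond further out reads butyl to propyl. Among the compounds with values here, no pair of measured compounds shows this change, so nothing here sets its size. The expected step is a 1.2-fold higher number from compound 1 to compound 4 (0.07 log units; within the scatter), nothing beyond the scatter. On that basis compound 4 is expected to give about 0.8 mg/kg, within a range from 0.4 mg/kg to 1.6 mg/kg.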

Compound 4, dose for 50% inhibition: 0.52 mg/kg
Compound 4: the middle estimate sits 1.5-fold (0.19 log units) above what was measured, within the range that was stated.
By their numbers in this assay, from the lowest: compounds 3, 2, 4 and 1 (each within the scatter of the next, the first and the last beyond it).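

Cutting the butyl chain to propyl gives a 1.3-fold lower number from compound 1 to compound 4 (0.12 log units; within the scatter) in this assay. This is the first pair shown that differs in one place, and it shows that this chain tolerates the loss of one methyl with no change beyond the scatter. No measurement here accounts for this result. The compounds shown leave open how far the chain can be altered at this place: a shorter ethyl group, a longer pentyl chain or a chain ending in an amine remains to be compared with compound 1.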